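Compound 4: Thiophen-3-yl in Place of Nitro

The source may report more compounds than this note shows. Statements on the series, on what has been measured and on what is new or still open speak of the compounds shown alone.

Measured in an assay on isolated protein for displacement of a labelled ligand from 5-hydroxytryptamine receptor 1B (Rattus norvegicus); on this read-out higher numbers stand for weaker inhibition and lower numbers for stronger inhibition:
compound 1 `Cc1[nH]c2ccc(F)cc2c1C1=CCNCC1` gives 200 nM
compound 2 `Cc1[nH]c2ccccc2c1C1=CCNCC1` gives 890 nM
compound 3 `Cc1[nH]c2ccc([N+](=O)[O-])cc2c1C1=CCNCC1` gives 570 nM

On these numbers compound 3 stands second highest of three: its nearest neighbour is compound 2, a step within the scatter, and its furthest is compound 1, a step beyond the scatter.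

Compound 4 `Cc1[nH]c2ccc(-c3ccsc3)cc2c1C1=CCNCC1` differs from compound 3 in one place: thiophen-3-yl in place of nitro on an aromatic carbon. For the measured compounds named here, the steps that bear on this position are those that vary the same aromatic carbon. From compound 1 to compound 3 the change was a 2.9-fold higher number from compound 1 to compound 3 (0.45 log units; beyond the scatter), and from compound 2 to compound 3 it was a 1.6-fold lower number from compound 2 to compound 3 (0.19 log units; within the scatter). Going by the values given here, neither involves a ring entering at that carbon, so there is no direct precedent for thiophen-3-yl; the measured steps only show that the position tolerates exchange of small groups with modest shifts in this assay. Compound 4 is therefore expected to land near compound 3, with a step of a 1.3-fold lower number from compound 3 to compound 4 (0.10 log units; within the scatter) and wide uncertainty. The estimate for compound 4 is 450 nM, in the range 100 nM to 2000 nM.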

Compound 4, half-maximal inhibitory concentration: 12 nM
Compound 4: the middle estimate sits 38-fold (1.57 log units) above what was measured, and the stated range ends above it.
By their numbers in this assay, from the lowest: compound 4; then compound 1; then compounds 3 and 2 (each within the scatter of the next).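

In this assay, thiophen-3-yl at this aromatic carbon brings a shift far larger than any seen among the small groups (a 48-fold lower number from compound 3 to compound 4 (1.68 log units; beyond the scatter)), and the same holds against hydrogen (a 74-fold lower number from compound 2 to compound 4 (1.87 log units; beyond the scatter)) and fluoro (a 17-fold lower number from compound 1 to compound 4 (1.22 log units; beyond the scatter)). Exchanges among hydrogen, fluoro and nitro had moved the number by modest steps at most, so this position can carry a much larger change than those compounds showed. Nothing in the data on hand accounts for the size of this shift.

With only one ring at this carbon, the compounds shown leave open whether the shift belongs to thiophen-3-yl itself or to aromatic rings here in general. A phenyl ring, thiophen-2-yl or a furan ring at the same carbon would address that, and an amine or a carboxylic acid on the ring would extend the question further.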